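The compounds below may be only part of what the source reports. "The series", "measured", "known", "first", "only" and "open" are said of these compounds alone.

Compound 1, `CCCn1c(=O)n(CCN(C)C)c(=O)c2[nH]cnc21`, gives 4300 nM in an assay on Cerebral cortex for binding affinity to adenosine receptor A1 (Cavia porcellus), read by radioligand binding; a higher number here means a weaker inhibitor, a lower number a stronger inhibitor.
Compound 2, `CCCn1c(=O)n(CCC(C)=O)c(=O)c2[nH]cnc21`, gives 11200 nM in this assay.
Compound 3, `CCCn1c(=O)n(C)c(=O)c2c1ncn2CCCN(C)C`, gives only a limit in this assay, > 200000 nM.

Among these three, compound 3 is the one whose result is not a number: its reading is a limit, as recorded in the limit of > 200000 nM in this assay, at which 1 of the 3 values shown sits, so its true weakness is not resolved. Compound 4, `CCCn1c(=O)n(C)c(=O)c2c1ncn2CCC(C)=O`, differs from compound 3 in one place: acetyl in place of (dimethylamino)methyl on a saturated chain carbon, two bonds along the chain from an aromatic nitrogen. Within the data shown here, the one measured step that bears on this exchange is the one between compound 1 and compound 2, where an acetyl likewise replaced a dimethylamino on the chain carried by an aromatic nitrogen: a 2.6-fold higher number from compound 1 to compound 2 (0.42 log units; beyond the scatter). The same kind of exchange is therefore expected to shift compound 4 by a modest amount in the weakening direction, or by nothing that rises above the scatter. Since compound 3 already sits at a limit, compound 4 is expected to give only a limit again in this assay. My estimate for compound 4 is 400000 nM, with a range from 150000 nM to 1500000 nM. The step this implies, a step that the limit leaves unreadable from compound 3 to compound 4, is an expectation only, not a measurement.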

Compound 4, inhibition constant: 30000 nM
Compound 4: the middle estimate sits 13-fold (1.12 log units) above what was measured; the measured number lies below the stated range.
By their numbers in this assay, from the lowest: compound 1; then compound 2; then compound 4. At a limit, above all of these: compound 3.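

At this position, on a saturated chain carbon two bonds along the chain from an aromatic nitrogen, acetyl in place of (dimethylamino)methyl gives an at least 6.6-fold lower number from compound 3 to compound 4 (0.82 log units; beyond the scatter) in this assay. The earlier exchange of a dimethylamino group for an acetyl ran the opposite way, a 2.6-fold higher number from compound 1 to compound 2 (0.42 log units; beyond the scatter), so this kind of change does not bring one fixed shift: its direction differs between these two pairs, whose chains stand at different places on the shared core. The true size of the new step stays unresolved because compound 3 gives only a limit: the limit of > 200000 nM in this assay, at which 1 of the 4 values shown sits.

Going by these compounds, it remains open whether the acetyl itself matters or whether removing the amine is enough, and a plain butyl chain or an alcohol at this place would help tell those two readings apart. Also open, on these data alone, is whether a longer chain ending in acetyl, or a cyclic amine such as piperidine in place of the dimethylamino group, would move the number further in either direction.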